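Iodo for Isopropyl on the Urea Aryl Ring

The source may report more compounds than this note shows. Statements on the series, on what has been measured and on what is new or still open speak of the compounds shown alone.

Within the data shown here, compound 2 `CC(C)c1ccc(NC(=O)N[C@@H](C)c2ccccc2)cc1` gives 86% in an ADME assay on the whole organism with Oryza sativa as the target, tested at 10 uM (a higher number here means a weaker effect of the compound at the concentration tested, a lower number a stronger effect), the second highest of the three numbers measured so far; compound 3 stands above it beyond the scatter, compound 1 well below it. Compound 1 `CC(C)c1ccc(NC(=O)N[C@H](C)c2ccccc2)cc1` gives 49% in this assay. Among the measured compounds shown here, the only measured step between two compounds that differ in one place is a number 37 percentage points higher from compound 1 to compound 2 (beyond the scatter), and it rests on (the fact that compounds 1 and 2 differ only in the configuration as drawn), with no change of substituents at all. Compound 3 `C[C@H](NC(=O)Nc1ccccc1I)c1ccccc1` gives 98% in this assay and is the nearest number to compound 2.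

Compound 4 `C[C@H](NC(=O)Nc1ccc(I)cc1)c1ccccc1` has not yet been measured. Against compound 2 the change is iodo in place of isopropyl on an aromatic carbon. For the measured compounds named here, no measured step touches this substituent, so the stereo step from compound 1 to compound 2 gives no guide to its size or direction. What the values do show is that compound 3, the other iodo-bearing urea, sits higher than compound 2 beyond the scatter, while the two ring patterns are not the same. On that basis a modest rise is expected, near the edge of the scatter: a number 6 percentage points higher from compound 2 to compound 4 (within the scatter) is the expected step. Compound 4 is estimated at 92% in this assay, with a range from 76% to 100%.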

Compound 4, a percentage reported as activity, at one concentration (the size of the read-out at that concentration, not a potency): 95%
Compound 4: the middle estimate sits 3 percentage points below what was measured; the measured number falls inside the stated range.
By their numbers in this assay, from the lowest: compound 1; then compounds 2, 4 and 3 (each within the scatter of the next, the first and the last beyond it).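

In this assay, among these compounds, iodo in place of isopropyl gives a number 9 percentage points higher from compound 2 to compound 4 (within the scatter) and is the first substituent change read at this position, on an aromatic carbon para to a large group. Among the compounds shown here, in the configuration of compound 2, a group of 3 heavy atoms and a group of 1 heavy atom therefore cannot be told apart in this assay, and a number 37 percentage points higher from compound 1 to compound 2 (beyond the scatter) remains the only single-place step beyond the scatter. No information at hand bears on a cause for the iodo step, and the configurational relationship between compounds 1 and 2 says nothing about this substituent change.

Compound 1 is the only compound shown in its configuration, so it remains open whether iodo at this position would give a number near that of compound 1 or whether the low number depends on isopropyl as well as on the configuration. Also open, going by these compounds, is how an amine, a carboxylic acid or a longer chain at this position would read in this assay in either configuration.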